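This account rests on a few compounds, and the source may have more. Where it says the series, first, only, none or still open, it means among the compounds named here.

Compound 2 `CC1=C(/C=N/NC(N)=S)C(C)(C)CC=C1` gives 74500 nM in an assay on cells for inhibition of Amine oxidase [flavin-containing] B (Homo sapiens), read by fluorescence and spectrophotometry, with a stated time of 20 min (on this read-out higher numbers stand for weaker inhibition and lower numbers for stronger inhibition), the lowest of the three numbers shown, though all three lie within the scatter of one another: compound 1 `CC1=C(/C=N/NC(N)=O)C(C)(C)CC=C1` gives 111000 nM, and compound 3 `CC1=C(/C=N/N(C)C(N)=S)C(C)(C)CC=C1` gives 117000 nM. Compound 4 `CC1=C(/C=N/NC(=S)Nc2ccccc2)C(C)(C)CC=C1` has not yet been measured; it differs from compound 2 by phenyl in place of hydrogen on an amide-type nitrogen, that is, amino to anilino. The step that bears most on it is the earlier substitution on the amide-type nitrogen, a 1.6-fold higher number from compound 2 to compound 3 (0.20 log units; within the scatter); the change from carbonyl to thiocarbonyl, a 1.5-fold lower number from compound 1 to compound 2 (0.17 log units; within the scatter), was likewise within the scatter. Nothing in these three compounds points to a step beyond the scatter in either direction. Compound 4 is therefore expected to give about 60000 nM, within a range of 15000 nM to 250000 nM. This estimate means an expected step of a 1.2-fold lower number from compound 2 to compound 4 (0.09 log units; within the scatter).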

Compound 4, half-maximal inhibitory concentration: 224000 nM
For compound 4 the middle estimate is 3.7-fold (0.57 log units) below the measured one; measured number inside the range.
By their numbers in this assay, from the lowest: compounds 2, 1, 3 and 4 (each within the scatter of the next, the first and the last beyond it).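

Going by these compounds alone, a phenyl group on the amide-type nitrogen whose other neighbour is the thiocarbonyl carbon gives the first step beyond the scatter in this set: in this assay, amino to anilino brings a 3.0-fold higher number from compound 2 to compound 4 (0.48 log units; beyond the scatter), a modest loss of inhibition. The earlier steps shown here did not show that the series could respond to a change at all. No evidence at hand accounts for this step. Going by these compounds, whether a smaller ethyl or a larger benzyl group here would give a similar step remains open, as does whether a chlorophenyl group would. Also open, on these data alone, is how anilino behaves with carbonyl in place of thiocarbonyl.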